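The source may report more compounds than this note shows. Statements on the series, on what has been measured and on what is new or still open speak of the compounds shown alone.

Working notes on the series in an ADME assay on L02 cells (Homo sapiens) for inhibition, read by CCK-8 assay, with a stated time of 48 h; a higher number here means a weaker inhibitor of growth, a lower number a stronger inhibitor of growth. Compound 1 `Cc1ccccc1Nc1nc(Nc2cccnc2)ncc1Cl` gives 22900 nM. Compound 2 `Cc1ccccc1Nc1nc(NCc2ccccc2)ncc1Cl` is reported only as a limit of the assay, > 100000 nM. Among the compounds with values here, the single change between them, benzyl in place of pyridin-3-yl on a nitrogen on an aromatic ring, gives an at least 4.3-fold higher number from compound 1 to compound 2 (0.64 log units; beyond the scatter); the size of that step rests on (the limit of > 100000 nM in this assay, at which 1 of the 3 values shown sits). Compound 3 `CN1CCN(c2ccc(Nc3ncc(Cl)c(NCc4ccc(C(F)(F)F)cc4)n3)nc2)CC1` gives 26200 nM, the higher of the two numbers shown, with compound 1 as its nearest neighbour and within the scatter of it.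

Compound 4 `CC(C)c1cccc(Nc2nc(Nc3ccc(N4CCN(C)CC4)cn3)ncc2Cl)c1` differs from compound 3 in one place: 3-isopropylphenyl in place of 4-(trifluoromethyl)benzyl on a nitrogen on an aromatic ring. Within the data shown here, the only measured step that bears on this change is the one from compound 1 to compound 2, which runs the opposite way, a benzyl-type group entering in place of an aromatic ring bound directly to the nitrogen, and which gave an at least 4.3-fold higher number from compound 1 to compound 2 (0.64 log units; beyond the scatter). Here the benzyl-type group leaves and an aromatic ring directly on the nitrogen enters, so a lower number is expected, although the entering group is 3-isopropylphenyl rather than pyridin-3-yl, which leaves the size of the step open. The step from compound 3 to compound 4 is expected to be a 2.2-fold lower number from compound 3 to compound 4 (0.34 log units; beyond the scatter). Compound 4 is therefore expected to give about 12000 nM, with a range from 4000 nM to 40000 nM.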

Compound 4, concentration for 50% growth inhibition: 12500 nM
Estimate against measurement, compound 4: 1.0-fold (0.02 log units) below; the measured number falls inside the stated range.
By their numbers in this assay, from the lowest: compounds 4, 1 and 3 (each within the scatter of the next, the first and the last beyond it). At a limit, above all of these: compound 2.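

In this assay, 3-isopropylphenyl in place of 4-(trifluoromethyl)benzyl on this nitrogen gives a 2.1-fold lower number from compound 3 to compound 4 (0.32 log units; beyond the scatter). The direction matches an at least 4.3-fold higher number from compound 1 to compound 2 (0.64 log units; beyond the scatter), so the higher number goes with the benzyl-type group in both pairs that test this kind of change, one on the core of compound 1 and one on the core of compound 3, and neither pair goes against it. Compound 2 is a limit of the assay, so the earlier step has no defined size, whereas the new step rests on a number at both ends and gives the first defined size for a change of this kind at this position: the limit of > 100000 nM in this assay, at which 1 of the 4 values shown sits.

No measured property among the compounds shown accounts for the new step. Going by these compounds, the step changes the connection to the nitrogen and the substituent on the ring together, so their separate shares stay open, as does the reading of an unsubstituted phenyl, a 3-(trifluoromethyl)phenyl or a phenyl carrying a carboxylic acid at this nitrogen.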